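A few compounds are considered here, and "the series" means these few. Any claim that something is new, unique, unknown or untested is made for them only; others in the source may bear on it.

Measured so far in an assay on liver for inhibition of sterol O-acyltransferase 1 (Rattus norvegicus), using microsomes; on this read-out higher numbers stand for weaker inhibition and lower numbers for stronger inhibition:
compound 1 `CC(C)c1cccc(C(C)C)c1NC(=O)NS(=O)(=O)N1CCCC1` gives 15000 nM
compound 2 `CCCCCCNS(=O)(=O)NC(=O)Oc1c(C(C)(C)C)cc(C)cc1C(C)(C)C` gives 19400 nM
compound 3 `CCCCCCN(CCCCCC)S(=O)(=O)NC(=O)Oc1c(C(C)(C)C)cc(C)cc1C(C)(C)C` gives 4300 nM

Compound 2 stands at the highest of the three numbers. Compound 1 lies within the scatter of it, so no order can be drawn between those two. For the measured compounds named here, compound 3 lies beyond the scatter: a 4.5-fold lower number from compound 2 to compound 3 (0.65 log units; beyond the scatter), the only change followed in this assay so far, hexyl in place of hydrogen on a sulfonamide nitrogen.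

Compound 4 `CCCCCCOS(=O)(=O)NC(=O)Oc1c(C(C)(C)C)cc(C)cc1C(C)(C)C` has not yet been measured in this assay. It differs from compound 2 in one place: hexyloxy in place of hexylamino on a sulfonyl sulfur. Going by the values given here, the hexylamino group, which in compound 2 carries the hydrogen that compound 3 replaces, is here exchanged as a whole, so the step from compound 2 to compound 3 does not bear on this change directly, and no measured pair exchanges nitrogen for oxygen on the sulfonyl sulfur. Among the compounds with values here, with no precedent, the expectation for compound 4 is anchored on compound 2, and the expected step is a 1.3-fold lower number from compound 2 to compound 4 (0.11 log units; within the scatter), not beyond the scatter, with a wide range to either side. Compound 4 is therefore estimated at 15000 nM, between 5000 nM and 45000 nM.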

Compound 4, half-maximal inhibitory concentration: 95000 nM
Beside the measured number, compound 4's estimate is 6.3-fold (0.80 log units) below it; the measured number lies above the stated range.
By their numbers in this assay, from the lowest: compound 3; then compounds 1 and 2 (each within the scatter of the next); then compound 4.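

With the hexyl chain held constant in this assay, the exchange on the sulfonyl sulfur gives a 4.9-fold higher number from compound 2 to compound 4 (0.69 log units; beyond the scatter) and so shows that the atom joining the chain to the sulfur is not interchangeable at this position. For the compounds shown here, until now, the only followed change here was a 4.5-fold lower number from compound 2 to compound 3 (0.65 log units; beyond the scatter), so edits at this one site can now be seen to move the number in either direction from compound 2. The hexylamino group counts a hydrogen-bond donor and the hexyloxy group none, yet compound 3 also lacks the hydrogen on that nitrogen and moves the opposite way, so loss of that hydrogen alone does not account for the higher number in compound 4, and no supporting measurement bears on the cause of the step.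

Still open, as far as these compounds go, is how a hexylthio or heptyl group on the sulfonyl sulfur would compare with the hexylamino and hexyloxy groups. Also open, from the compounds shown here alone, is whether hexyloxy gives a similar step with a butyl or octyl chain in place of hexyl, or on the core of compound 1.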